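Amino group added to the core of compound 1

This account rests on a few compounds, and the source may have more. Where it says the series, first, only, none or still open, it means among the compounds named here.

Two compounds carry a chloromethyl-bearing benzyl group on a fused two-ring core. Compound 1 is `ClCc1ccc(Cn2cnc3c(Cl)ncnc32)cc1` and compound 2 is `ClCc1cccc(Cn2cnc3c(Cl)nc(Cl)nc32)c1`. In a functional assay on OVCAR-4 cells (Homo sapiens) for cytotoxicity, read by sulforhodamine B assay, with a stated time of 48 h (on this read-out lower numbers stand for stronger inhibition of growth and higher numbers for weaker inhibition of growth), compound 1 gives 2450 nM, the lowest of the two numbers shown, while compound 2 gives 5490 nM, a weaker number that lies beyond the scatter. Compound 3 is `Nc1nc(Cl)c2ncn(Cc3ccc(CCl)cc3)c2n1`; it differs from compound 1 by amino in place of hydrogen on an aromatic carbon, on an aromatic carbon of a six-membered aromatic ring with two nitrogen atoms, between two ring nitrogen atoms and meta to a chloro group. Going by the values given here, no measured pair shows what such a change does here, so the expected step from compound 1 to compound 3 is a 1.2-fold lower number from compound 1 to compound 3 (0.09 log units; within the scatter), with no direction beyond the scatter claimed. Compound 3 is therefore estimated at 2000 nM in this assay, within a range from 700 nM to 6000 nM.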

Compound 3, concentration for 50% growth inhibition: 15500 nM
The estimate for compound 3 lay 7.8-fold (0.89 log units) below the measured number; the whole stated range lies below it.
By their numbers in this assay, from the lowest: compound 1; then compound 2; then compound 3.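

In this assay the amino group on the aromatic carbon between two ring nitrogen atoms gives a 6.3-fold higher number from compound 1 to compound 3 (0.80 log units; beyond the scatter) and so weaker inhibition of growth. Going by these compounds alone, this is the first measured sign that this position is not indifferent to change: a swap that brings in only one heavy atom and one hydrogen-bond donor moves the number beyond the usual scatter. Nothing shown here explains the loss, so its cause remains unknown.

A single step at a single position cannot show whether the loss belongs to the amino group alone or would follow any group placed on this carbon. A methyl group, a methoxy group or a dimethylamino group at the same place would help to separate these two readings.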